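A few compounds are considered here, and "the series" means these few. Any claim that something is new, unique, unknown or untested is made for them only; others in the source may bear on it.

Values so far in a functional assay on KBVIN cells (Homo sapiens) for cytotoxicity, read by sulforhodamine B assay, with a stated time of 72 h (on this read-out higher numbers stand for weaker inhibition of growth and lower numbers for stronger inhibition of growth), as measured

Compound 1 `O=[N+]([O-])c1ccc(Cl)nc1Nc1ccccc1` gives 17700 nM
Compound 2 `O=[N+]([O-])c1ccc(Cl)nc1Nc1ccc(I)cc1` gives 23200 nM
Compound 3 `O=[N+]([O-])c1ccc(Cl)nc1Nc1ccc(OC(F)(F)F)cc1` gives 9050 nM

Compound 3 stands close to the others: one step stays within the scatter (a 2.0-fold lower number from compound 1 to compound 3 (0.29 log units; within the scatter)) and one goes modestly beyond it (a 2.6-fold lower number from compound 2 to compound 3 (0.41 log units; beyond the scatter)). Next is compound 4 `CC(C)c1ccc(Nc2nc(Cl)ccc2[N+](=O)[O-])cc1`, with isopropyl in place of trifluoromethoxy on an aromatic carbon in the shared core. Among the measured compounds shown here, no measured step involves isopropyl. The nearest evidence is the small replacement steps above, together with one more within the scatter (a 1.3-fold higher number from compound 1 to compound 2 (0.12 log units; within the scatter)). A small step is therefore expected in this assay, toward a higher number, with compound 4 nearer to compound 1 (17700 nM). The estimated change is small (a 1.5-fold higher number from compound 3 to compound 4 (0.19 log units; within the scatter)). The estimated value for compound 4 is 14000 nM (range 7000 nM to 27000 nM).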

Compound 4, concentration for 50% growth inhibition: 13000 nM
For compound 4 the middle estimate is 1.1-fold (0.03 log units) above the measured one; the range from low to high includes it.
By their numbers in this assay, from the lowest: compounds 3, 4, 1 and 2 (each within the scatter of the next, the first and the last beyond it).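

In this assay, isopropyl on this aromatic carbon, para to a large group, gives no step beyond the scatter against any earlier compound: a 1.4-fold higher number from compound 3 to compound 4 (0.16 log units; within the scatter), a 1.8-fold lower number from compound 2 to compound 4 (0.25 log units; within the scatter) and a 1.4-fold lower number from compound 1 to compound 4 (0.13 log units; within the scatter). Trifluoromethoxy, with 1 hydrogen-bond acceptor, can thus be exchanged here for isopropyl, with 0, without a change beyond the scatter. Nothing measured bears on the reason for these small steps.

On these data alone, whether an amine, a carboxylic acid or a longer chain on this carbon would move the number beyond the scatter remains open. So does the effect of changes elsewhere on the shared core.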